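The compounds below may be only part of what the source reports. "The series", "measured", "known", "first", "only" and "open" are said of these compounds alone.

Measured compounds in a functional assay on HEK293 cells for antagonist activity at transient receptor potential cation channel subfamily V member 1 (Homo sapiens), read by calcium flux; a higher number here means a weaker inhibitor, a lower number a stronger inhibitor:
compound 1 `FC(F)(F)c1ccc(Nc2ncnc3sc(Nc4c(Cl)cccc4Cl)nc23)cc1` gives 12 nM.
compound 2 `Clc1cccc(Cl)c1Nc1nc2c(Nc3ccccc3)ncnc2s1` gives 176 nM.
compound 3 `O=C(O)c1ccc(Nc2ncnc3sc(Nc4c(Cl)cccc4Cl)nc23)cc1` gives only a limit, > 5000 nM.

Compound 1 holds the lowest of the two numbers shown; the nearest is compound 2, a 15-fold higher number from compound 1 to compound 2 (1.17 log units; beyond the scatter). Compound 3 sits at the limit (the limit of > 5000 nM in this assay, at which 1 of the 3 values shown sits), so an at least 410-fold higher number from compound 1 to compound 3 (2.61 log units; beyond the scatter) and an at least 28-fold higher number from compound 2 to compound 3 (1.45 log units; beyond the scatter) are read as limits only.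

Compound 4 `FC(F)(F)c1ccc(Nc2ncnc3sc(Nc4c(Cl)cccc4Cl)nc23)cc1Cl` differs from compound 1 by chloro in place of hydrogen on an aromatic carbon. The measured steps all exchange the trifluoromethyl itself; none adds a chloro while keeping it, so none bears directly on this step. With the trifluoromethyl retained, no change beyond the scatter in this assay is expected, a 1.2-fold lower number from compound 1 to compound 4 (0.08 log units; within the scatter). Compound 4 is estimated at 10 nM, between 3 nM and 40 nM.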

Compound 4, half-maximal inhibitory concentration: 21 nM
Beside the measured number, compound 4's estimate is 2.1-fold (0.32 log units) below it; measured number inside the range.
By their numbers in this assay, from the lowest: compounds 1 and 4 (each within the scatter of the next); then compound 2. At a limit, above all of these: compound 3.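

In this assay, chloro in place of hydrogen, ortho to a trifluoromethyl group, gives a 1.8-fold higher number from compound 1 to compound 4 (0.24 log units; within the scatter). Within the data shown here, this position on the aromatic ring therefore accepts an added chloro with the trifluoromethyl retained, which the earlier steps, all exchanging the trifluoromethyl itself, could not show. No measured property bears on this step.

From the compounds shown here alone, whether an amine or a methoxy group at the same position would also stay within the scatter remains open. So does the effect of this chloro without the trifluoromethyl.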